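The source may hold more compounds than are shown below. What is called first, only, known or untested is meant among the compounds shown, and "the series" means these compounds.

Compound 1 `CNC(=O)c1cc(C(=O)NC2CC2)cc2c1OC[C@@]2(C)c1ccccc1` is the reference point of this account. In a physicochemical assay for solubility, read by HPLC, in simulated intestinal fluid, with a stated time of 16 h, at pH 6.5, tested at 2.5 mg/mL (on this read-out lower numbers stand for lower solubility and higher numbers for higher solubility), compound 1 gives 585 ug/mL, the higher of the two plain numbers in the set. Compound 3 `CNC(=O)c1cc(C(=O)N[C@H]2[C@@H]3COC[C@@H]32)cc2c1O[C@H](CF)[C@H]2c1ccccc1`, which carries a different core and the same bicyclic amide substituent as the target, gives 80 ug/mL in this assay, a gap to compound 1 that lies well beyond the scatter of repeated measurements. Compound 2 `CNC(=O)c1cc(C(=O)N[C@H]2C[C@@H]2C)cc2c1OC[C@@]2(CO)c1ccccc1` is reported in this assay only as a limit, > 1000 ug/mL, and not as a number. The set therefore holds (the limit of > 1000 ug/mL in this assay, at which 1 of the 3 values shown sits), so the upper end of the range is not resolved.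

The step under consideration leads to compound 4 `CNC(=O)c1cc(C(=O)N[C@H]2[C@@H]3COC[C@@H]32)cc2c1OC[C@@]2(C)c1ccccc1`. The change is a group of 6 heavy atoms (5 carbon, 1 oxygen; one three-membered non-aromatic ring of carbon only, one five-membered non-aromatic ring with 1 hetero atom) in place of a group of 3 heavy atoms (3 carbon; one three-membered non-aromatic ring of carbon only), on an amide-type nitrogen. The shared core of compound 1 is kept intact; only the amide-type nitrogen carries a different substituent.

For the measured compounds named here, no measured pair in this set isolates this change. Compound 3 carries the entering group but also a different core, so its value cannot be read as the effect of the substituent alone. A moderate downward step is expected for this assay, within roughly the scatter or somewhat beyond it, as a 1.7-fold lower number from compound 1 to compound 4 (0.22 log units; within the scatter). Compound 4 is accordingly estimated at 350 ug/mL, with a range from 120 ug/mL to 900 ug/mL.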

Compound 4, solubility: 80 ug/mL
For compound 4 the middle estimate is 4.4-fold (0.64 log units) above the measured one; measured number below the stated range.
By their numbers in this assay, from the lowest: compounds 3 and 4 (each within the scatter of the next); then compound 1. At a limit, above all of these: compound 2.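

For the compounds shown here, this pair gives the first reading of the amide-type nitrogen in which only the substituent differs: in this assay, with the shared core kept intact, replacing cyclopropyl with the larger group containing the five-membered ring gives a 7.3-fold lower number from compound 1 to compound 4 (0.86 log units; beyond the scatter), a step of modest size. Going by these compounds alone, until now, the entering group had been seen only in compound 3, on a different core, so no value could be assigned to the substituent alone. The step therefore shows that a change at this one place, with nothing else altered, is enough to move this read-out beyond the scatter, although nothing measured here gives a reason for it.

A single step on a single core cannot separate the part played by the added ring atoms from the part played by the ring oxygen, and it cannot show whether the same change would give a similar step on another core. A carbon-only counterpart of the entering group would address the first question, while a simple isopropyl group or a ring carrying an amine would show how other substituents at this nitrogen compare with cyclopropyl.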